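Methoxy to methoxycarbonyl on the benzyl ring: expected cytotoxicity

The compounds below may be only part of what the source reports. "The series", "measured", "known", "first", "only" and "open" are said of these compounds alone.

In an ADME assay on MT2 cells (Homo sapiens) for cytotoxicity, read by XTT assay, with a stated time of 4 days (on this read-out lower numbers stand for higher toxicity in this test and higher numbers for lower toxicity in this test), compound 1 `Cc1cc(/C=C2\SC(=S)N(Cc3ccccc3)C2=O)c(C)n1-c1ccc(O)c(C(=O)O)c1` gives 159000 nM, while compound 2 `COc1ccc(CN2C(=O)/C(=C/c3cc(C)n(-c4ccc(O)c(C(=O)O)c4)c3C)SC2=S)cc1` gives 75300 nM, the lowest of the two numbers. For the measured compounds named here, the one measured step, a 2.1-fold lower number from compound 1 to compound 2 (0.32 log units; beyond the scatter), is modest. Compound 3 `COC(=O)c1ccc(CN2C(=O)/C(=C/c3cc(C)n(-c4ccc(O)c(C(=O)O)c4)c3C)SC2=S)cc1` differs from compound 2 by methoxycarbonyl in place of methoxy on an aromatic carbon, placed para to a large group. Going by the values given here, no measured step trades methoxy for methoxycarbonyl, so that step offers only loose guidance. For compound 3 a change of a 1.1-fold lower number from compound 2 to compound 3 (0.03 log units; within the scatter) in this assay is expected, within the scatter. Compound 3 is therefore estimated at 70000 nM, ranging from 30000 nM to 180000 nM.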

Compound 3, half-maximal cytotoxic concentration: 36900 nM
For compound 3 the middle estimate is 1.9-fold (0.28 log units) above the measured one; the range from low to high includes it.
By their numbers in this assay, from the lowest: compound 3; then compound 2; then compound 1.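

In this assay the change from 4-methoxybenzyl to 4-(methoxycarbonyl)benzyl gives a 2.0-fold lower number from compound 2 to compound 3 (0.31 log units; beyond the scatter), so the number at this position, para to a large group, still moves when one substituent replaces another, not only when a substituent replaces hydrogen. With hydrogen as the reference, methoxycarbonyl gives a 4.3-fold lower number from compound 1 to compound 3 (0.63 log units; beyond the scatter), and both substituents shown lie on the same side of hydrogen. Nothing available explains this order. The compounds shown leave open whether an amine or a carboxylic acid at this position would move the number the same way.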